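Restoring a heteroaryl ketone on the unsaturated chain

The source may report more compounds than this note shows. Statements on the series, on what has been measured and on what is new or still open speak of the compounds shown alone.

Compound 2 `CCCCCCCC/C=C\CCCCCCCC(OC)OC` ends its unsaturated chain in a 2,2-dimethoxyethyl group. In an assay on isolated protein for inhibition of Fatty-acid amide hydrolase 1 (Homo sapiens) (on this read-out higher numbers stand for weaker inhibition and lower numbers for stronger inhibition), compound 2 reaches only the limit of the assay, > 300000 nM. Compound 1 `CCCCCCCC/C=C\CCCCCCC(=O)c1ccncn1` carries a (pyrimidin-4-yl)carbonyl group at the same place, and in this assay compound 1 gives 110 nM. The measured step between them is an at least 2700-fold higher number from compound 1 to compound 2 (3.43 log units; beyond the scatter), a step whose size is bounded only by the limit of > 300000 nM in this assay, at which 1 of the 2 values shown sits. Compound 3 `CCCCCCCC/C=C\CCCCCCC(=O)c1ncco1` differs from compound 2 by (1,3-oxazol-2-yl)carbonyl in place of 2,2-dimethoxyethyl on a saturated chain carbon, six bonds along the chain from a double-bonded chain carbon. This change runs against the kind of change seen in the step from compound 1 to compound 2, bringing back a heteroaryl ketone where the acetal stood, so in this assay a large step toward stronger inhibition is expected, an at least 3000-fold lower number from compound 2 to compound 3 (3.47 log units; beyond the scatter). Compound 3 is accordingly estimated at 100 nM in this assay, with a range from 15 nM to 700 nM.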

Compound 3, inhibition constant: 17 nM
Compound 3: the middle estimate sits 5.9-fold (0.77 log units) above what was measured; low and high end bracket the measured number.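

Compound 3 shows that this position does not depend on a pyrimidin-4-yl ketone: with 1,3-oxazol-2-yl on the carbonyl carbon, this assay records a 6.5-fold lower number from compound 1 to compound 3 (0.81 log units; beyond the scatter). A second heteroaryl ketone also stands far from the acetal, with an at least 17000-fold lower number from compound 2 to compound 3 (4.24 log units; beyond the scatter), and compound 2 is held at a limit, so the size of this step is only bounded: the limit of > 300000 nM in this assay, at which 1 of the 3 values shown sits. Both ketones thus read far stronger than the acetal, while the ring on the carbonyl carbon still shifts the number within that stronger range.

Compound 2 lacks the carbonyl and the ring together, and the compounds shown do not separate their shares. They also do not tell how a phenyl ketone, a carboxylic acid at the chain end or a longer chain would read in this assay.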